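Amide-acid series: phenylsulfanyl in place of isopropyl

This account rests on a few compounds, and the source may have more. Where it says the series, first, only, none or still open, it means among the compounds named here.

Measured so far:
compound 1, `CCCCCCCCCCCCCCCC(=O)N[C@@H](CC(=O)O)CC(C)C`, 7300 nM
compound 2, `CCCCCC/C=C/CC(=O)N[C@@H](CC(=O)O)CC(C)C`, 8500 nM

Both compounds share an amide-linked acid chain and differ in the acyl part. In an assay on isolated protein (Sus scrofa) with Group 10 secretory phospholipase A2 (Homo sapiens) as the target (on this read-out lower numbers stand for stronger inhibition and higher numbers for weaker inhibition), compound 1 gives 7300 nM. In this assay compound 2 gives 8500 nM; this is the higher of the two numbers, but its gap to compound 1 lies within the scatter, so the two cannot be told apart.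

Compound 3, `CCCCCC/C=C/CC(=O)N[C@H](CSc1ccccc1)CC(=O)O`, keeps the acyl chain of compound 2 and changes the side group: phenylsulfanyl in place of isopropyl on a saturated chain carbon, two bonds along the chain from an amide-type nitrogen. Going by the values given here, no measured pair shows this change, so its size cannot be read from the data. The two measured numbers sit close together, and nothing here points to a direction for this new change. The expectation is therefore a step of a 1.4-fold lower number from compound 2 to compound 3 (0.15 log units; within the scatter), small and of uncertain sign, with a wide range.

For compound 3 in this assay the estimate is 6000 nM, within 1500 nM to 25000 nM.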

Compound 3, half-maximal inhibitory concentration: 2200 nM
Compound 3: middle estimate off by 2.7-fold (0.44 log units), on the high side; the range from low to high includes it.
By their numbers in this assay, from the lowest: compound 3; then compounds 1 and 2 (each within the scatter of the next).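

In this assay, going by these compounds alone, the swap of isopropyl for phenylsulfanyl on a saturated chain carbon, two bonds along the chain from an amide-type nitrogen, gives a 3.9-fold lower number from compound 2 to compound 3 (0.59 log units; beyond the scatter) and is the only step so far, which makes this side-group position a place where the number responds to a change. The entering group brings one six-membered aromatic ring and a sulfur atom together, with 7 heavy atoms against 3, so this single pair cannot separate the contribution of the ring, the sulfur or the added size. No measurement available here bears on why the number falls at this position.

Still open, going by these compounds, is which part of the group carries the step: phenoxy or benzyl in place of phenylsulfanyl would test the sulfur, and methylsulfanyl would test the aromatic ring. Also open, on these data alone, is whether the same step appears on the saturated acyl chain of compound 1, and whether a substituent such as chloro or methoxy on the phenyl ring moves the number further.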